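A few compounds are considered here, and "the series" means these few. Any claim that something is new, unique, unknown or untested is made for them only; others in the source may bear on it.

Three compounds have been measured in an ADME assay on J774 cells (Mus musculus) for cytotoxicity, read by MTT assay, with a stated time of 48 h; on this read-out higher numbers stand for weaker inhibition and lower numbers for stronger inhibition:

compound 1, `O=C(CN1CCCC1)NCCNc1cc(/C=C/c2ccccc2)nc2ccccc12`, gives 12500 nM
compound 2, `O=C(CN1CCCC1)NCCCCNc1cc(/C=C/c2ccccc2)nc2ccccc12`, gives 7100 nM
compound 3, `O=C(CNc1ccccc1)NCCNc1cc(/C=C/c2ccccc2)nc2ccccc12`, gives 7800 nM

Compound 3 is compound 1 with one change, (anilino in place of pyrrolidin-1-yl on a saturated chain carbon bound to a carbonyl carbon). That change produced a 1.6-fold lower number from compound 1 to compound 3 (0.20 log units; within the scatter), so compounds 1 and 3 cannot be told apart on this read-out. Among the measured compounds shown here, compound 2 carries a different core from compound 1; the difference between the two cores is not broken down here, and no step is given for that pair, so their values can only be read side by side. Compound 4, `O=C(CNc1ccccc1)NCCCCNc1cc(/C=C/c2ccccc2)nc2ccccc12`, has not yet been measured. It differs from compound 2 by anilino in place of pyrrolidin-1-yl on a saturated chain carbon bound to a carbonyl carbon, which is the same change already seen between compounds 1 and 3, made at the same place. Because the earlier step was a 1.6-fold lower number from compound 1 to compound 3 (0.20 log units; within the scatter), the step from compound 2 to compound 4 is expected to be of similar size, a 1.6-fold lower number from compound 2 to compound 4 (0.20 log units; within the scatter). Compound 4 is therefore estimated at 4500 nM in this assay, with a likely range from 1800 nM to 11000 nM.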

Compound 4, half-maximal inhibitory concentration: 3300 nM
For compound 4 the middle estimate is 1.4-fold (0.13 log units) above the measured one; the measured number falls inside the stated range.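

In this assay, anilino in place of pyrrolidin-1-yl on the second core gives a 2.2-fold lower number from compound 2 to compound 4 (0.33 log units; beyond the scatter), a modest step. Set beside the step on the first core, the new step does not differ from it, so on these two cores the change carries over at a similar size: the same change on two cores in this assay, a 1.6-fold lower number (0.20 log units; within the scatter) from compound 1 to compound 3 and a 2.2-fold lower number (0.33 log units; beyond the scatter) from compound 2 to compound 4, 1.3-fold (0.13 log units) apart, within the scatter of two such steps

This rests on two pairs only, and the step on the first core lies within the scatter when taken alone, so it does not show that the change would lower the number on every core in this series, and it does not show why the number moves. The compounds shown leave open whether the same agreement would hold for other groups at this place, such as piperidin-1-yl, morpholin-4-yl or a chloro-substituted anilino. Among the compounds shown here, they also leave open whether it would survive on a core with a longer chain than the one in compound 2.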